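Lengthening the chain and dropping the aromatic ring

This account rests on a few compounds, and the source may have more. Where it says the series, first, only, none or still open, it means among the compounds named here.

Compounds measured so far:
compound 1, `O=c1[nH]/c(=N\OCCOc2ccccc2)ccn1[C@@H]1O[C@H](COP(=O)(O)OP(=O)(O)OP(=O)(O)O)[C@@H](O)[C@H]1O`: 430 nM
compound 2, `O=c1[nH]/c(=N\OCCCc2cccc(I)c2)ccn1[C@@H]1O[C@H](COP(=O)(O)OP(=O)(O)OP(=O)(O)O)[C@@H](O)[C@H]1O`: 114 nM
compound 3, `O=c1[nH]/c(=N\OCCCc2cccc([N+](=O)[O-])c2)ccn1[C@@H]1O[C@H](COP(=O)(O)OP(=O)(O)OP(=O)(O)O)[C@@H](O)[C@H]1O`: 95 nM

In a functional assay on 1321-N1 cells for agonist activity at P2Y purinoceptor 4 (Homo sapiens), read by scintillation counting and inositol phosphate accumulation (a higher number here means that more compound is needed for the effect, a lower number that less compound is needed), compound 3 gives the lowest number of the three, though its gap to compound 2 is small: a 1.2-fold lower number from compound 2 to compound 3 (0.08 log units; within the scatter). Against compound 1 the gap is clearer, a 4.5-fold lower number from compound 1 to compound 3 (0.66 log units; beyond the scatter), and compound 2 stands in much the same way, a 3.8-fold lower number from compound 1 to compound 2 (0.58 log units; beyond the scatter).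

Compound 4, `C#CCCCO/N=c1/ccn([C@@H]2O[C@H](COP(=O)(O)OP(=O)(O)OP(=O)(O)O)[C@@H](O)[C@H]2O)c(=O)[nH]1`, has not yet been measured. It differs from compound 3 by ethynyl in place of 3-nitrophenyl on a saturated chain carbon, three bonds along the chain from an oxygen. Among the compounds with values here, none of the measured steps removes the aromatic ring altogether; the two steps from compound 1 show that exchanging the ring-bearing chain end shifts the number modestly, and the step from compound 2 to compound 3 shows that the group on the ring hardly matters. Since the three measured compounds all keep an aromatic ring, the effect of removing it entirely is uncertain, and a step going in the opposite direction to the two modest gains from compound 1 is considered plausible.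

Compound 4 is therefore expected to give a somewhat higher number, a 4.2-fold higher number from compound 3 to compound 4 (0.62 log units; beyond the scatter), with the estimate placed at 400 nM and a range from 120 nM to 1500 nM.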

Compound 4, half-maximal effective concentration: 410 nM
Beside the measured number, compound 4's estimate is 1.0-fold (0.01 log units) below it, within the range that was stated.
By their numbers in this assay, from the lowest: compounds 3 and 2 (each within the scatter of the next); then compounds 4 and 1 (each within the scatter of the next).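

In this assay, within the data shown here, ethynyl in place of 3-nitrophenyl gives a 4.3-fold higher number from compound 3 to compound 4 (0.64 log units; beyond the scatter) and ethynyl in place of 3-iodophenyl gives a 3.6-fold higher number from compound 2 to compound 4 (0.56 log units; beyond the scatter) on the same saturated chain carbon, so for the first time this position is seen without any aromatic ring, and the loss of the substituted ring moves the number by a modest step beyond the scatter. Propargyl in place of phenoxy gives a 1.0-fold lower number from compound 1 to compound 4 (0.02 log units; within the scatter) and this shows that a chain end with no ring at all can stand level with the phenoxy chain end, which means that an aromatic ring alone does not set compounds 2 and 3 apart from compound 1 or from compound 4. No independent measurement is available to explain these differences.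

The compounds shown leave open whether the lower numbers of compound 2 and compound 3 depend on the phenyl ring itself or on its iodo and nitro groups, a question that an unsubstituted phenyl on the same chain would address. They also leave open how a saturated propyl end, an amine, a carboxylic acid or a longer chain ending in ethynyl would compare at this position.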